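The source may report more compounds than this note shows. Statements on the series, on what has been measured and on what is new or still open speak of the compounds shown alone.

Measured so far in a functional assay on ECa-109 cells for inhibition, with ECa-109 cell line (Homo sapiens) as the target, read by sulforhodamine B assay; on this read-out lower numbers stand for stronger inhibition and higher numbers for weaker inhibition:
compound 1 `O=C1C(Nc2cccc(Cl)c2)=CC(=O)c2c1nc1n2[C@H]2OC[C@@H](O)[C@H]2OC1`: 3080 nM
compound 2 `COc1cccc(NC2=CC(=O)c3nc4n(c3C2=O)[C@H]2OC[C@@H](O)[C@H]2OC4)c1`: 7620 nM
compound 3 `COc1ccccc1NC1=CC(=O)c2c(nc3n2[C@H]2OC[C@@H](O)[C@H]2OC3)C1=O`: > 4000 nM

Compound 2 holds the higher of the two numbers shown in this assay; the number for compound 1 is the lower one, and the gap between them lies beyond the scatter. Compound 3 is reported only as a limit in this assay, not as a number, so the limit of > 4000 nM in this assay, at which 1 of the 3 values shown sits, marks the point at which its value sits. Going by the values given here, the one step with both ends defined in one place is an at least 1.2-fold higher number from compound 1 to compound 3 (0.11 log units; that floor lies within the scatter), and its floor lies within the scatter.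

Compound 4 `CCCc1ccc(NC2=CC(=O)c3nc4n(c3C2=O)[C@H]2OC[C@@H](O)[C@H]2OC4)cc1` is the next member to be read in this assay. Its difference from compound 2 is 4-propylphenyl in place of 3-methoxyphenyl on an amine nitrogen. Among the compounds with values here, no measured step covers this exchange: the only step on record swaps groups on the same amine nitrogen but involves neither 3-methoxyphenyl nor 4-propylphenyl, and the aryl changes seen so far span a range that stays close to the scatter or ends at a limit. The expectation for this assay is therefore a step of about a 1.1-fold lower number from compound 2 to compound 4 (0.04 log units; within the scatter), that is, no movement clearly beyond the scatter in either direction. Compound 4 is estimated at 7000 nM, with a range from 2500 nM to 20000 nM.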

Compound 4, half-maximal inhibitory concentration: > 4000 nM
Compound 4 was reported as a limit (the forecaster's own chance of this, stated with the estimate: 30%); the middle value lies beyond the limit too.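

In this assay compound 4 is reported only as a limit, so no step from compound 2 to compound 4 can be read: the limit of > 4000 nM in this assay, at which 2 of the 4 values shown sit.

The compounds shown leave open whether 4-propylphenyl in place of 3-methoxyphenyl on the amine nitrogen changes the number at all and, if it does, in which direction.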